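The compounds below may be only part of what the source reports. "The series", "measured", "known", "first", "only" and "open" are said of these compounds alone.

Compound 1 `CC(C)(O/N=C(\C(=O)N[C@@H]1C(=O)N(S(=O)(=O)O)[C@@H]1CNC(=O)CN)c1csc(N)n1)C(=O)O` in a physicochemical assay for metabolic stability, read by HPLC and mass spectrometry, in phosphate buffer, at 37 degrees C, at pH 7.4 (a higher number here means that the compound lasts longer, a lower number that the compound disappears faster), gives 149 h. Of the two values in this set that are numbers, that of compound 1 is the lower, but its nearest neighbour compound 2 `CC(C)(O/N=C(\C(=O)N[C@@H]1C(=O)N(S(=O)(=O)O)[C@@H]1Cn1cncn1)c1csc(N)n1)C(=O)O`, which in this assay gives 233 h, sits only a 1.6-fold higher number from compound 1 to compound 2 (0.19 log units; within the scatter) away, a gap the scatter swallows; the change there is 1H-1,2,4-triazol-1-yl in place of ((aminomethyl)carbonyl)amino on a saturated chain carbon bound to a saturated ring carbon. Compound 3 `CC(C)(O/N=C(\C(=O)N[C@@H]1C(=O)N(S(=O)(=O)O)[C@@H]1CN1C[C@H](CN)OC1=O)c1csc(N)n1)C(=O)O` in this assay returns only a limit, > 37 h. Both a step that the limit leaves unreadable from compound 1 to compound 3 and a step that the limit leaves unreadable from compound 2 to compound 3 therefore cannot be sized due to the limit of > 37 h in this assay, at which 1 of the 3 values shown sits.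

Compound 4 `CC(C)(O/N=C(\C(=O)N[C@@H]1C(=O)N(S(=O)(=O)O)[C@@H]1CN1C[C@H](CNC(=N)N)OC1=O)c1csc(N)n1)C(=O)O` is not yet measured. Against compound 1 the change is a group of 11 heavy atoms (5 carbon, 4 nitrogen, 2 oxygen; one five-membered non-aromatic ring with 2 hetero atoms) in place of a group of 5 heavy atoms (2 carbon, 2 nitrogen, 1 oxygen; no ring), on a saturated chain carbon bound to a saturated ring carbon. The measured steps that bear on it both start from compound 1: one is within the scatter and the other is unreadable, so no step beyond the scatter is foreseen in either direction. The step of a 1.0-fold higher number from compound 1 to compound 4 (0.00 log units; within the scatter) is the expectation. For compound 4 in this assay the estimate is 150 h, with a range from 60 h to 400 h; a limit rather than a number remains a real possibility.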

Compound 4, half-life: > 37 h
Compound 4 gave a limit, no number; the forecaster's own chance of this, stated with the estimate: 30%; the middle value does not contradict the limit.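

In this assay compound 4 gives > 37 h, a limit and not a number, so its steps from compound 1, compound 2 and compound 3 cannot be read: the limit of > 37 h in this assay, at which 2 of the 4 values shown sit.

Still open, going by these compounds, is how compound 3 and compound 4, which differ by a group on an amine nitrogen, stand against each other and against compound 1 and compound 2 in this assay.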